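Metabolic Stability of Compound 3, Estimated Before Measurement

The source may hold more compounds than are shown below. What is called first, only, known or untested is meant among the compounds shown, and "the series" means these compounds.

In an ADME assay on microsomes from liver (Homo sapiens) for metabolic stability, read by LC-MS, using NADPH, with a stated time of 45 min, tested at 0.5 uM (on this read-out higher numbers stand for fast clearance and lower numbers for slow clearance), compound 1 `CS(=O)(=O)C1CCN(C(=O)CCSc2nc3cc(Cl)ccc3o2)C1` gives only a limit, < 0.4 mL/min/g. Among the compounds with values here, compound 2 `O=C(CCSc1nc2ccccc2o1)N1CCCC1` is the sole compound with a number: in this assay compound 2 gives 5.1 mL/min/g. Within the data shown here, the one other value shown sits at the limit of < 0.4 mL/min/g in this assay, at which 1 of the 2 values shown sits. Compound 3 `O=C(CCSc1nc2cc(F)ccc2o1)N1CCCC1` has not yet been measured in this assay. It differs from compound 2 by fluoro in place of hydrogen on an aromatic carbon. Among the measured compounds shown here, with no measured step to guide it, the expected change is a 1.3-fold lower number from compound 2 to compound 3 (0.11 log units; within the scatter), small and not clearly beyond the scatter in either direction. Compound 3 is therefore estimated at 4 mL/min/g in this assay, within 1.5 mL/min/g to 9 mL/min/g.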

Compound 3, intrinsic clearance in a liver preparation (reported as CLH), per the amount of preparation that the assay uses: 5.2 mL/min/g
Estimate against measurement, compound 3: 1.3-fold (0.11 log units) below, within the range that was stated.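

Fluoro in place of hydrogen on an aromatic carbon, meta to a fused ring and para to a fused ring, gives a 1.0-fold higher number from compound 2 to compound 3 (0.01 log units; within the scatter) in this assay. Within the data shown here, this is the first measured step at this position, and it shows that the position takes fluoro with no clearance difference that stands out from the scatter. Nothing at hand gives a reason for this result.

From the compounds shown here alone, whether methoxy, a nitrile or an amine at this position would read the same stays open. So does whether fluoro on another aromatic carbon of that ring would.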